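Adding a Methyl to Compound 2

A few compounds are considered here, and "the series" means these few. Any claim that something is new, unique, unknown or untested is made for them only; others in the source may bear on it.

Compound 1 `COc1cccc(/C=C2\CNC/C(=C\c3cccc(OC)c3)C2=O)c1` gives 4300 nM
Compound 2 `CCN(CC)c1ccc(/C=C2\CNC/C(=C\c3ccc(N(CC)CC)cc3)C2=O)cc1` gives 35000 nM
Compound 3 `CN1C/C(=C\c2ccc(Cl)cc2)C(=O)/C(=C/c2ccc(Cl)cc2)C1` gives 10000 nM

In a functional assay on L1210 cells (Mus musculus) for inhibition, read by MTT assay, with a stated time of 72 h (a higher number here means a weaker inhibitor, a lower number a stronger inhibitor), compound 2 gives 35000 nM and so has the highest number of the three. It is the weakest inhibitor of the set, and its gaps to compound 3 and to compound 1 both lie beyond the scatter.

Compound 4 `CCN(CC)c1ccc(/C=C2\CN(C)C/C(=C\c3ccc(N(CC)CC)cc3)C2=O)cc1` departs from compound 2 in a single place, (methyl in place of hydrogen on an amine nitrogen in a ring), that is, methyl in place of hydrogen on an amine nitrogen in a ring. Going by the values given here, no pair of measured compounds shows this change on its own. Among the compounds with values here, the one measured compound with a methyl in that place is compound 3 at 10000 nM but it carries different groups elsewhere, so it gives only a weak hint toward a lower number.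

In this assay a small shift toward a lower number is therefore expected, with no step beyond the scatter. The estimated change is a 1.6-fold lower number from compound 2 to compound 4 (0.20 log units; within the scatter) and it is expected to remain small. For compound 4 the expected value is 22000 nM with an estimated range from 8000 nM to 50000 nM.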

Compound 4, half-maximal inhibitory concentration: 3300 nM
Estimate against measurement, compound 4: 6.7-fold (0.82 log units) above, outside the stated range (below it).
By their numbers in this assay, from the lowest: compounds 4 and 1 (each within the scatter of the next); then compound 3; then compound 2.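

Going by these compounds alone, this is the first matched reading of the change: in this assay, methyl in place of hydrogen on an amine nitrogen in a ring gives an 11-fold lower number from compound 2 to compound 4 (1.03 log units; beyond the scatter), a large step beyond the scatter, with everything else in the structure held constant. The earlier compounds shown here carried different groups elsewhere and so could offer only a weak hint about this position, whereas this pair shows that, in the core of compound 2, a single added carbon on this nitrogen is enough on its own to move the number substantially and toward a stronger inhibitor. Nothing in the data shown gives a measured property that would account for a step of this size.

As far as these compounds go, whether the same change acts to a similar extent with the different groups elsewhere in compound 1 remains open, since that compound has no matched partner here. From the compounds shown here alone, it is also open whether the trend continues with a longer chain on this nitrogen, such as ethyl or benzyl, or whether an acetyl group there would keep or lose the gain.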